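A few compounds are considered here, and "the series" means these few. Any claim that something is new, unique, unknown or untested is made for them only; others in the source may bear on it.

Measured compounds in a functional assay on HEp-2 cells (Homo sapiens) for cytotoxicity, with a stated time of 24 h; on this read-out lower numbers stand for stronger inhibition and higher numbers for weaker inhibition:

Compound 1, `O=C(Nc1ccccc1)c1c(-c2ccc(Cl)cc2)c(-c2ccccc2)nn1-c1ccccc1`: 0.74 ug/mL
Compound 2, `O=C(c1c(-c2ccccc2)c(-c2ccccc2)nn1-c1ccccc1)n1c(=S)[nH]c2ccccc21`: 7.18 ug/mL

Compound 2 has the highest number of the two in this assay, and the nearest number, that of compound 1, is far lower, a gap well beyond the usual scatter of repeated measurements. Compound 1 and compound 2 differ in two places at once, so what these two values show cannot be traced to a single change.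

Compound 3, `O=C(c1c(-c2ccc(Cl)cc2)c(-c2ccccc2)nn1-c1ccccc1)n1c(=S)[nH]c2ccccc21`, has not yet been measured in this assay. It differs from compound 2 in one place: chloro in place of hydrogen on an aromatic carbon. For the measured compounds named here, no step between two measured compounds that differ only in this way is available, so the size and direction of the step remain open. Going by the values given here, the one measured compound that carries the chloro group, compound 1, gives 0.74 ug/mL, but its second difference from compound 2 blurs the reading. A step of modest size toward stronger inhibition is expected, a 1.8-fold lower number from compound 2 to compound 3 (0.25 log units; within the scatter), though a result within the scatter would not surprise. Compound 3 is therefore estimated at 4 ug/mL, with a range from 1.5 ug/mL to 12 ug/mL.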

Compound 3, half-maximal inhibitory concentration: 1.54 ug/mL
Compound 3: the middle estimate sits 2.6-fold (0.41 log units) above what was measured, and the stated range covers the measured number.
By their numbers in this assay, from the lowest: compound 1; then compound 3; then compound 2.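

The 4-chlorophenyl change can now be read alone: in this assay, swapping phenyl for 4-chlorophenyl gives a 4.7-fold lower number from compound 2 to compound 3 (0.67 log units; beyond the scatter), so this single chloro group on the aromatic ring, placed para to a large group, shifts the number by more than the usual scatter. With the chloro group held constant, the group on the carbonyl carbon can also be read by itself: placing the sulfur-bearing group of 10 heavy atoms where the group of 7 heavy atoms stood gives a 2.1-fold higher number from compound 1 to compound 3 (0.32 log units; beyond the scatter), a modest step that is also beyond the scatter. This shows that both places on the molecule affect the result in this assay, but nothing available explains why either change moves the number.

On these data alone, whether bromo, methoxy or an amine in this same place would shift the number in the same direction, or by a similar amount, remains open. As far as these compounds go, the chloro step also rests on one pair of compounds, so it is unknown whether the same step would appear with the carbonyl group of compound 1.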